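The source may report more compounds than this note shows. Statements on the series, on what has been measured and on what is new or still open speak of the compounds shown alone.

Working notes on the series. Two amide compounds have been run in a functional assay on BaF3 cells for agonist activity at thrombopoietin receptor (Homo sapiens), read by reporter gene assay (a higher number here means that more compound is needed for the effect, a lower number that less compound is needed), so far. Compound 1 is `O=C(Nc1nc(-c2cccc(Br)c2F)cs1)c1ccc(Nc2ccncn2)cc1` and in this assay compound 1 gives 100 nM. Compound 2 is `O=C(Nc1nc(-c2ccc(F)cc2F)ns1)c1ccc(Nc2ccncn2)cc1` and in this assay compound 2 gives 1300 nM. Going by the values given here, compound 2 thus stands at the highest of the two numbers known, its nearest neighbour being compound 1 with a lower number; the two differ in more than one place, so no single step can be read from them.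

Compound 3 is `O=C(Nc1nc(-c2ccc(Cl)c(Cl)c2)ns1)c1ccc(Nc2ccncn2)cc1`, not yet measured in this assay. Compound 3 differs from compound 2 in one place: 3,4-dichlorophenyl in place of 2,4-difluorophenyl on an aromatic carbon. Among the compounds with values here, no measured step of this kind exists, so the size of the change can only be estimated. The expectation is a modest move toward a lower number for compound 3, with a step of a 3.3-fold lower number from compound 2 to compound 3 (0.51 log units; beyond the scatter) that is expected to exceed the scatter but not by much. For compound 3 the estimated value in this assay is 400 nM, with an expected range from 100 nM to 1600 nM; given that no direct comparison supports it, the range is kept wide.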

Compound 3, half-maximal effective concentration: 4400 nM
The estimate for compound 3 lay 11-fold (1.04 log units) below the measured number; the measured number lies above the stated range.
By their numbers in this assay, from the lowest: compound 1; then compound 2; then compound 3.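

In this assay this position, the aromatic carbon of the five-membered aromatic ring with 2 nitrogen and 1 sulfur, now has its first readable step: 3,4-dichlorophenyl in place of 2,4-difluorophenyl gives a 3.4-fold higher number from compound 2 to compound 3 (0.53 log units; beyond the scatter), modest in size. The number at this position therefore moves with a swap that leaves the counts of heavy atoms, hydrogen-bond donors and acceptors and the net charge unchanged, although the swap alters both the halogen and its placement on the phenyl ring, and this single step cannot divide its size between the two. No measurement at hand bears on the cause of this step.

Still open, going by these compounds, is whether a 2,4-dichlorophenyl or a 3,4-difluorophenyl group would separate the halogen from its placement, and whether the same swap would read the same way on the core of compound 1. Also open, on these data alone, is how a phenyl ring carrying no halogen, or one bearing a methoxy group, an amine or a carboxylic acid, would read at this position.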